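The compounds below may be only part of what the source reports. "The series", "measured", "known", "first", "only" and "open" are said of these compounds alone.

Measured compounds:
compound 1 `O=Cc1ccc(-c2cn3ccnc3c(-c3ccc4ncn(C5CCCCC5)c4c3)n2)cc1` with 3.69%
compound 2 `O=Cc1ccc(-c2cn3ccnc3c(-c3ccc4ncn(Cc5ccccc5)c4c3)n2)cc1` with 3.69%
compound 3 `c1cn2cc(-c3ccc4c(c3)ncn4C3CCCCC3)nc(-c3ccc4ncn(C5CCCCC5)c4c3)c2n1` with 30.6%

Three compounds were tested in a functional assay on KM12 cells (Homo sapiens) for inhibition, read by sulforhodamine B assay, with a stated time of 48 h, tested at 10 uM; on this read-out higher numbers stand for more inhibition at the one concentration tested (going by the name of the read-out) and lower numbers for less inhibition. Compound 1 and compound 2 share a core carrying a carbaldehyde on one end; they differ only by benzyl in place of cyclohexyl on an aromatic nitrogen, and no change at the digits printed from compound 1 to compound 2 (within the scatter). Compound 3 is built on a different core, and how that core differs from the core of compound 1 is not broken down here; in this assay compound 3 gives 30.6%, the highest of the three numbers, with its steps to compound 1 and to compound 2 lying beyond the scatter.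

Compound 4 `c1ccc(Cn2cnc3ccc(-c4nc(-c5ccc6c(c5)ncn6C5CCCCC5)cn5ccnc45)cc32)cc1` has not yet been measured. It differs from compound 3 by benzyl in place of cyclohexyl on an aromatic nitrogen, the same change that separates compound 1 from compound 2, at the same kind of place. Because that earlier change gave no change at the digits printed from compound 1 to compound 2 (within the scatter), compound 4 is expected to stay close to compound 3, with a step of about a number 2.6 percentage points lower from compound 3 to compound 4 (within the scatter). The estimate for compound 4 in this assay is therefore 28%, expected to fall between 10% and 45%.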

Compound 4, a percentage reported as inhibition, at one concentration (the size of the read-out at that concentration, not a potency): -39.4%
Beside the measured number, compound 4's estimate is 67.4 percentage points above it; the measured number lies below the stated range.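

In this assay, the change from cyclohexyl to benzyl on an aromatic nitrogen gave a number 70 percentage points lower from compound 3 to compound 4 (beyond the scatter), so its outcome on the core of compound 1 could not be carried over to the core of compound 3. The two cores answer differently to the same change: the same change on two cores in this assay, no change at the digits printed (within the scatter) from compound 1 to compound 2 and a number 70 percentage points lower (beyond the scatter) from compound 3 to compound 4, 70 percentage points apart, beyond the scatter of two such steps. This shows that, for these two pairs, the size of the step depends on the core; it does not show which part of the cores is responsible, and one pair per core gives no rule for any further core.

The compounds shown leave open whether the difference between the pairs follows from the carbaldehyde carried by compound 1 and compound 2 or from the cyclohexyl-bearing group that takes its place in compound 3 and compound 4. They also leave open how an amine or a carboxylic acid at that end, or a longer chain such as phenethyl on the aromatic nitrogen, would read in this assay.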